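The compounds below may be only part of what the source reports. "The series", "measured", "known", "first", "only" and "open" are said of these compounds alone.

Measured so far in an assay for inhibition of RAC-alpha serine/threonine-protein kinase (Homo sapiens), read by HTRF, with a stated time of 1 h; a lower number here means a stronger inhibitor, a higher number a weaker inhibitor:

- compound 1 `Cn1ncc(Cl)c1-c1cc(C(=O)N[C@@H]2CN[C@H](CCN3CCCC3)C[C@H]2c2ccc(Cl)c(Cl)c2)oc1Cl`: 6.41 nM
- compound 2 `Cn1ncc(Cl)c1-c1cc(C(=O)N[C@@H]2CN[C@H](CC(=O)NC3CCC3)C[C@H]2c2ccc(Cl)c(Cl)c2)oc1Cl`: 7.98 nM
- compound 3 `CNC(=O)C[C@@H]1C[C@@H](c2ccc(Cl)c(Cl)c2)[C@H](NC(=O)c2cc(-c3c(Cl)cnn3C)c(Cl)o2)CN1`: 2.64 nM

Compound 3 holds the lowest number of the three, and both of its steps lie beyond the scatter: a 2.4-fold lower number from compound 1 to compound 3 (0.39 log units; beyond the scatter) and a 3.0-fold lower number from compound 2 to compound 3 (0.48 log units; beyond the scatter). The two larger substituents at this position sit close together, a 1.2-fold higher number from compound 1 to compound 2 (0.10 log units; within the scatter), so the spread across the whole set at the saturated chain carbon bound to a saturated ring carbon is modest.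

Compound 4 `Cn1ncc(Cl)c1-c1cc(C(=O)N[C@@H]2CN[C@H](CC(O)CO)C[C@H]2c2ccc(Cl)c(Cl)c2)oc1Cl` is the next variant at that same position. Its change from compound 3 reads (1,2-dihydroxyethyl in place of methylcarbamoyl on a saturated chain carbon bound to a saturated ring carbon).

Going by the values given here, the steps that bear on this are the two into compound 3, since all three measured compounds differ only at this chain carbon. They show that a basic amine, a cyclobutyl amide and a methyl amide all stay within a narrow band of this assay numbers, with the smallest group giving the lowest number. Among the compounds with values here, no measured step covers a diol in place of an amide, so the expectation rests on the overall tolerance of this position. A small step is expected, with a slight lean toward a higher number than compound 3, as a 1.9-fold higher number from compound 3 to compound 4 (0.28 log units; within the scatter).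

For compound 4 the expected number in this assay is 5 nM, with a range from 2 nM to 15 nM.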

Compound 4, half-maximal inhibitory concentration: 3.79 nM
For compound 4 the middle estimate is 1.3-fold (0.12 log units) above the measured one; measured number inside the range.
By their numbers in this assay, from the lowest: compounds 3, 4, 1 and 2 (each within the scatter of the next, the first and the last beyond it).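

Going by these compounds alone, the 1,2-dihydroxyethyl group is the first group at this saturated chain carbon to carry no nitrogen, and in this assay the exchange for methylcarbamoyl gives a 1.4-fold higher number from compound 3 to compound 4 (0.16 log units; within the scatter). The exchange for the (pyrrolidin-1-yl)methyl group also stays inside the scatter, at a 1.7-fold lower number from compound 1 to compound 4 (0.23 log units; within the scatter), whereas the exchange for cyclobutylcarbamoyl gives a 2.1-fold lower number from compound 2 to compound 4 (0.32 log units; beyond the scatter), so among the compounds shown an amide or amine nitrogen in this group is not needed to reach the level of compound 3 and compound 4 sits clear only of compound 2. Nothing at hand explains these numbers or ties them to any property of the groups.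

On these data alone, it remains open whether one hydroxyl alone, as a hydroxymethyl group, or a carboxylic acid on this carbon would hold the same level in this assay, and whether a longer chain ending in the same diol would do so. As far as these compounds go, the structure of compound 4 also assigns no configuration at the hydroxyl-bearing carbon of the diol, so any difference between the two separate stereoisomers at that carbon remains unknown.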